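The compounds below may be only part of what the source reports. "The series", "measured", "known", "first", "only" and "open" are said of these compounds alone.

Measured so far in an ADME assay on GES1 cells (Homo sapiens) for inhibition, read by MTT assay, with a stated time of 72 h; a lower number here means a stronger inhibitor, a higher number a weaker inhibitor:
- compound 1 `Cc1cc(Nc2ccn(Cc3ccccc3)n2)n2nc(SCc3ccc(Br)cc3)nc2n1`: 44400 nM
- compound 2 `Cc1cc(Nc2cc(-c3ccccc3)[nH]n2)n2nc(SCc3csc4ccccc34)nc2n1`: 29200 nM

Compound 1 holds the higher of these two numbers, but the gap to compound 2 lies within the scatter of repeated measurements, so the two cannot be ranked. They also differ in more than one place, so they give no direct measure of what a single small change does.

Compound 3 `Cc1ccc(Cn2ccc(Nc3cc(C)nc4nc(SCc5ccc(Br)cc5)nn34)n2)cc1` keeps the structure of compound 1 except for one change: methyl in place of hydrogen on an aromatic carbon. In words, benzyl becomes 4-methylbenzyl. Within the data shown here, with no measured single-change step to guide the size, no shift beyond the scatter in this assay is expected, in either direction, and the estimate stays close to compound 1 at 44400 nM. The expected change is a 1.1-fold lower number from compound 1 to compound 3 (0.05 log units; within the scatter). For compound 3 the estimated value is 40000 nM, with an expected range of 18000 nM to 90000 nM.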

Compound 3, half-maximal inhibitory concentration: > 50000 nM
Compound 3: only a limit was reported; the forecaster's own chance of this, stated with the estimate: 15%; middle value at least 1.2-fold (0.09 log units) from the limit.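

In this assay compound 3 gives a limit of the assay and not a number: > 50000 nM. Among these compounds, this is the first step in the set that changes one place only, benzyl to 4-methylbenzyl, and it can be read only as a floor, an at least 1.1-fold higher number from compound 1 to compound 3 (0.05 log units; that floor lies within the scatter), so the methyl gives no sign of a lower number, but the true size of the step stays unknown. The step cannot be sized further because the reading of compound 3 stops at a limit: the limit of > 50000 nM in this assay, at which 1 of the 3 values shown sits.

Still open, on these data alone, is whether the true number of compound 3 lies close to that of compound 1 or far from it. The compounds shown also leave open what an amine, a carboxylic acid or a longer chain on the same aromatic carbon would do to the number.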